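Pentyl homologue between two tolerated chain lengths

This account rests on a few compounds, and the source may have more. Where it says the series, first, only, none or still open, it means among the compounds named here.

Measured compounds in an ADME assay on HEL cells (Homo sapiens) for cytotoxicity, with a stated time of 3 days; a higher number here means that more compound is tolerated, a lower number that less compound is tolerated:
- compound 1 `CCCCCCc1ccc(-c2cc3cn([C@H]4C[C@H](O)[C@@H](CO)O4)c(=O)nc3o2)nc1` gives > 100000 nM, a limit of the assay.
- compound 2 `CCCCc1ccc(-c2cc3cn([C@H]4C[C@H](O)[C@@H](CO)O4)c(=O)nc3o2)nc1` gives > 100000 nM, also a limit of the assay.

Compound 2 carries a butyl chain on the pyridine; compound 1 carries the longer chain. In this assay compound 2 stands only at a limit, and the step that the two limits leave unreadable from compound 1 to compound 2 cannot be read because the limit of > 100000 nM in this assay, at which 2 of the 2 values shown sit, is where both values sit. Compound 3 `CCCCCc1ccc(-c2cc3cn([C@H]4C[C@H](O)[C@@H](CO)O4)c(=O)nc3o2)nc1` is the homologue in between, differing from compound 2 by methyl in place of hydrogen on a saturated chain carbon, four bonds along the chain from an aromatic carbon. Among the measured compounds shown here, the only measured step bearing on this change is the one from compound 1 to compound 2, and it gives no readable size; it does, however, show that both shorter and longer chains remain tolerated at the limit. No step beyond the scatter is therefore expected; the step of a number no higher from compound 2 to compound 3 (the limit leaves the size open) is estimated as flat. Compound 3 is expected to give about 100000 nM in this assay, most likely again reported as a limit, within the range 50000 nM to 200000 nM.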

Compound 3, minimum cytotoxic concentration: > 100000 nM
Compound 3 gave a limit, no number; the forecaster's own chance of this, stated with the estimate: 90%; the middle value lies on the limit itself.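

No step among compound 1, compound 2 and compound 3 can be read in this assay, because all three values are limits of the assay: the limit of > 100000 nM in this assay, at which 3 of the 3 values shown sit.

The compounds shown leave open at what concentration any of these chains becomes cytotoxic, and whether chain length alters that concentration.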